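A few compounds are considered here, and "the series" means these few. Any claim that something is new, unique, unknown or untested is made for them only; others in the source may bear on it.

In a toxicity assay on MT2 cells (Homo sapiens) for cytotoxicity (a higher number here means that more compound is tolerated, a lower number that less compound is tolerated), compound 1 `Cc1nc(C)c([C@H](OC(C)(C)C)C(=O)O)c(N2CCC(C)(C)CC2)c1C1=CCN(CCCc2ccc(F)cc2)CC1` gives >= 22000 nM, which is a limit of the assay and not a number. Compound 2 `Cc1cccc(F)c1CN1CCc2cc(-c3c(C)nc(C)c([C@H](OC(C)(C)C)C(=O)O)c3N3CCC(C)(C)CC3)ccc2C1` gives >= 24000 nM in this assay, again a limit rather than a number. Compound 2 therefore stands only at a limit, and both values shown sit at limits (the limit of >= 22000 nM in this assay, at which 1 of the 2 values shown sits; (the limit of >= 24000 nM in this assay, at which 1 of the 2 values shown sits)). Compound 3 `Cc1nc(C)c([C@H](OC(C)(C)C)C(=O)O)c(N2CCC(C)(C)CC2)c1-c1ccc2c(c1)CCN(Cc1ccc(F)cc1F)C2` differs from compound 2 by 2,4-difluorophenyl in place of 2-fluoro-6-methylphenyl on a saturated chain carbon bound to an amine nitrogen in a ring. Among the measured compounds shown here, no step in this assay is measured here; the expected step is none beyond the scatter, a number no higher from compound 2 to compound 3 (the limit leaves the size open). Compound 3 is accordingly estimated at 24000 nM, ranging from 12000 nM to 50000 nM, most likely again reported only as a limit.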

Compound 3, half-maximal cytotoxic concentration: >= 24000 nM
Compound 3: a limit, no number; the forecaster's own chance of this, stated with the estimate: 85%; the middle value sits exactly at the limit.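

No step can be read from compound 2 to compound 3, since both values are limits and not numbers: the limit of >= 24000 nM in this assay, at which 2 of the 3 values shown sit.

The compounds shown leave open how much of either compound is tolerated, and whether 2,4-difluorobenzyl in place of 2-fluoro-6-methylbenzyl changes that at all.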